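Cyclopentyl to hydroxypropyl on the amino nitrogen: working notes

The source may report more compounds than this note shows. Statements on the series, on what has been measured and on what is new or still open speak of the compounds shown alone.

Measured in a functional assay on MV4-11 cells (Homo sapiens) for antiproliferative activity, read by MTT assay; on this read-out higher numbers stand for weaker inhibition of growth and lower numbers for stronger inhibition of growth:
- compound 1 `COc1ccc(Nc2nc(NCCCO)c3ccccc3n2)cc1`: 8750 nM
- compound 2 `COc1ccc(N(C)c2nc(NC3CCCC3)c3ccccc3n2)cc1`: 2700 nM

Of these two numbers, compound 2 has the lower one at 2700 nM, and its gap to compound 1 lies beyond the scatter. Among the measured compounds shown here, the two compounds differ in more than one place, so no single-change step between measured compounds is available.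

The next compound to be tested is compound 3 `COc1ccc(N(C)c2nc(NCCCO)c3ccccc3n2)cc1`. It follows from compound 2 by one change, 3-hydroxypropyl in place of cyclopentyl on a nitrogen on an aromatic ring.

For the measured compounds named here, the only guide to this change is compound 1, which carries the same (3-hydroxypropyl)amino group and gives 8750 nM. On that thin basis, a modest move towards weaker inhibition of growth in this assay is expected, only just beyond the scatter. The expected step is a 2.2-fold higher number from compound 2 to compound 3 (0.35 log units; beyond the scatter). Compound 3 is estimated at 6000 nM, with an expected range of 2500 nM to 14000 nM.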

Compound 3, concentration for 50% growth inhibition: 70100 nM
Estimate against measurement, compound 3: 12-fold (1.07 log units) below, outside the stated range (above it).
By their numbers in this assay, from the lowest: compound 2; then compound 1; then compound 3.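

In this assay, the change from cyclopentylamino to (3-hydroxypropyl)amino now has a direct reading: the number rises by a 26-fold higher number from compound 2 to compound 3 (1.41 log units; beyond the scatter) with the methyl group held constant, a large loss of growth inhibition that compound 1 alone gave no measure of. The methyl in place of hydrogen on a nitrogen on an aromatic ring also matters in the presence of the 3-hydroxypropyl group, giving an 8.0-fold higher number from compound 1 to compound 3 (0.90 log units; beyond the scatter) as a further modest loss. With the 3-hydroxypropyl group in place, growth inhibition is therefore stronger with hydrogen than with methyl on that nitrogen, though nothing available explains either step.

From the compounds shown here alone, whether the methyl step carries the same direction and size alongside cyclopentyl remains open, since the present pair reads it only alongside 3-hydroxypropyl. Also open, going by these compounds, is whether the large step follows from the loss of the ring or from the terminal hydroxyl, a question that a plain propyl chain, a cyclohexyl ring or a 3-aminopropyl chain on the same nitrogen could help to separate.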